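The compounds below may be only part of what the source reports. "The series", "measured", "known", "first", "only" and "open" are said of these compounds alone.

Compound 1 `COc1cc2c(cc1OC)CN(CCCCc1cn(-c3ccc(F)cc3)c3ccccc13)C2`: 256 nM
Compound 2 `FCCOc1ccc(N2CCN(CCCCc3cn(-c4ccc(F)cc4)c4ccccc34)CC2)cc1`: 614 nM

In an assay on brain for displacement of a labelled ligand from Sigma non-opioid intracellular receptor 1 (Rattus norvegicus) (on this read-out higher numbers stand for weaker inhibition and lower numbers for stronger inhibition), compound 2 gives the higher of the two numbers; compound 1 stands below it by a gap beyond the usual scatter. Compound 3 `FCCOCCOc1ccc(N2CCN(CCCCc3cn(-c4ccc(F)cc4)c4ccccc34)CC2)cc1` differs from compound 2 by 2-fluoroethoxy in place of fluoro on a saturated chain carbon, two bonds along the chain from an oxygen on an aromatic ring. Within the data shown here, no pair of measured compounds isolates this change, so no measured step guides the expectation. The step expected in this assay is small, no larger than the scatter and with no direction asserted: a 1.2-fold lower number from compound 2 to compound 3 (0.09 log units; within the scatter). Compound 3 is therefore expected to give about 500 nM in this assay, in the range 200 nM to 1500 nM.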

Compound 3, inhibition constant: 1110 nM
Beside the measured number, compound 3's estimate is 2.2-fold (0.35 log units) below it; the measured number falls inside the stated range.
By their numbers in this assay, from the lowest: compound 1; then compounds 2 and 3 (each within the scatter of the next).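

In this assay, 2-fluoroethoxy in place of fluoro on a saturated chain carbon, two bonds along the chain from an oxygen on an aromatic ring, gives a 1.8-fold higher number from compound 2 to compound 3 (0.26 log units; within the scatter) and so leaves the read-out within the scatter. This position therefore accepts the added 2-fluoroethoxy without a step beyond the scatter. No measured evidence bears on this step.

As far as these compounds go, whether a hydroxyl or an amine at this chain carbon would stay within the scatter remains open. Also open, from the compounds shown here alone, is whether a longer chain would do so.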